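Swapping an aryl urea end for a diethanolamine

A few compounds are considered here, and "the series" means these few. Any claim that something is new, unique, unknown or untested is made for them only; others in the source may bear on it.

Compound 1 `COc1cc(NC(C)CCCNC(=O)NNC(=O)Nc2ccc(Cl)c(C(F)(F)F)c2)c2ncccc2c1`: 63%
Compound 2 `CCOC(=O)NC(c1ccccc1)c1ccc(Cl)cc1`: 21%
Compound 3 `COc1cc(NC(C)CCCNC(=O)NNC(=O)NCCNC(c2ccccc2)(c2ccccc2)c2ccccc2)c2ncccc2c1`: 88%

In a physicochemical assay for inhibition, read by spectrophotometry, tested at 100 uM (a higher number here means more inhibition at the concentration tested (going by the name of the read-out), a lower number less inhibition), compound 1 gives 63% and stands second of the three numbers shown. Compound 3 gives a value in this assay of 88%, a gap beyond the scatter, while compound 2 gives 21% in this assay, the lowest of the set and also beyond the scatter from compound 1.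

Compound 4 `COc1cc(NC(C)CCCNC(=O)NNC(=O)N(CCO)CCO)c2ncccc2c1` keeps the core of compound 1 and changes one end of the chain: bis(2-hydroxyethyl)amino in place of (4-chloro-3-(trifluoromethyl)phenyl)amino on a carbonyl carbon. For the measured compounds named here, no pair of measured compounds differs in a single place, so there is no measured step to lean on; what is known is that the bulkier end of compound 3 sits higher than compound 1 and the small compound 2 sits lowest.

On that footing a downward step is expected, of moderate size, a number 18 percentage points lower from compound 1 to compound 4 (beyond the scatter). Compound 4 is estimated to give about 45% in this assay, within a range of 20% to 72%.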

Compound 4, a percentage reported as inhibition, at one concentration (the size of the read-out at that concentration, not a potency): 43%
For compound 4 the middle estimate is 2 percentage points above the measured one; the measured number falls inside the stated range.
By their numbers in this assay, from the lowest: compound 2; then compound 4; then compound 1; then compound 3.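

In this assay, the end of the chain on the carbonyl carbon now has its first measured single change: bis(2-hydroxyethyl)amino in place of (4-chloro-3-(trifluoromethyl)phenyl)amino gives a number 20 percentage points lower from compound 1 to compound 4 (beyond the scatter). The number therefore responds to this end of the chain, yet inhibition does not vanish when the aromatic ring goes, since compound 4 still gives 43% in this assay. Nothing measured here explains why the number moves with this change.

The change replaces the whole end group at once, so the step cannot be divided between losing the substituted ring and gaining the two hydroxyethyl arms. Going by these compounds, whether a plain phenylamino end, without chlorine or trifluoromethyl, or a morpholine on the same carbonyl carbon would fall nearer compound 1 or compound 4 remains open.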